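Chain length and terminal group changes in the stomach series

The source may hold more compounds than are shown below. What is called first, only, known or untested is meant among the compounds shown, and "the series" means these compounds.

Measured in a functional assay on the whole organism (stomach) with Rattus norvegicus as the target; a lower number here means that less compound is needed, a higher number that more compound is needed for the effect:
- compound 1, `N#CNC(=N)NCCCCCn1nc(-c2ccccc2)ccc1=O`: > 100 mg/kg, a limit of the assay
- compound 2, `CN(C)/C(=N/CCCn1nc(-c2ccccc2)ccc1=O)NC#N`: 53 mg/kg
- compound 3, `CC(C)C/N=C(\S)NCCCCn1nc(-c2ccccc2)ccc1=O`: > 100 mg/kg, a limit of the assay

Within the data shown here, compound 1 stands only at a limit in this assay, and two of the three values so far sit at that limit (the limit of > 100 mg/kg in this assay, at which 2 of the 3 values shown sit). Compound 4, `CN(C)/C(=N/CCCCCCn1nc(-c2ccccc2)ccc1=O)NC#N`, is not yet measured. It differs from compound 1 as follows (a group of 9 heavy atoms (5 carbon, 4 nitrogen; no ring) in place of a group of 6 heavy atoms (2 carbon, 4 nitrogen; no ring), on a saturated chain carbon, five bonds along the chain from an aromatic nitrogen).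

Among the measured compounds shown here, two measured steps bear on this. The step of an at least 1.8-fold lower number from compound 1 to compound 2 (0.27 log units; that floor lies within the scatter) brings in the same dimethyl terminal arrangement that compound 4 carries, but on a shorter chain, and its floor lies within the scatter. The step that the two limits leave unreadable from compound 1 to compound 3 gives no readable size. For the measured compounds named here, compound 2 is the only compound with a number rather than a limit, so the expectation rests mainly on it.

Compound 4 is therefore expected to show a step of an at least 1.6-fold lower number from compound 1 to compound 4 (0.22 log units; that floor lies within the scatter), which is read as a lower number than the limit of compound 1 but not far from the value of compound 2. The estimate for compound 4 is 60 mg/kg, with a range from 25 mg/kg to 150 mg/kg.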

Compound 4, dose for half-maximal effect: 93.1 mg/kg
Beside the measured number, compound 4's estimate is 1.6-fold (0.19 log units) below it; the range from low to high includes it.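

In this assay, the group with 1 hydrogen-bond donor, placed on a saturated chain carbon, five bonds along the chain from an aromatic nitrogen, gives a measured number, yet the change amounts to an at least 1.0-fold lower number from compound 1 to compound 4 (0.03 log units; that floor lies within the scatter). Compound 1 is only a limit of the assay at > 100 mg/kg, and the true size of this step stays unreadable because its floor rests on that limit: the limit of > 100 mg/kg in this assay, at which 2 of the 4 values shown sit. What compound 4 adds is a second number for the same terminal arrangement on a longer chain: compound 2 gives 53 mg/kg and compound 4 gives 93.1 mg/kg, so this terminal group yields a measurable dose on both chains, with no order claimed between them.

As far as these compounds go, whether chain length itself matters with this terminal group stays open, since only these two chain lengths carry a number. How a chain longer than that of compound 4 would read, or a primary amine or a carboxylic acid in place of the terminal group, also remains unknown from the compounds shown.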